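Chloro for methoxy on the pendant aryl of compound 1

The source may report more compounds than this note shows. Statements on the series, on what has been measured and on what is new or still open speak of the compounds shown alone.

Compound 1 `COc1ccc(-c2cs/c(=N\NC(=O)c3ccc(O)cc3)n2-c2ccc(OC)cc2OC)cc1` is measured in a functional assay on OVCAR-3 cells (Homo sapiens) for cytotoxicity, read by sulforhodamine B assay, with a stated time of 48 h (a higher number here means a weaker inhibitor of growth, a lower number a stronger inhibitor of growth), and gives 17000 nM, the lowest of the three numbers in hand. For the measured compounds named here, compound 2 `O=C(c1ccc(O)cc1)n1nc(-c2c(Cl)cccc2Cl)sc1=S` gives 28800 nM in this assay, a number that lies within the scatter of the one for compound 1. Compound 3 `Cc1ccc(-c2cs/c(=N\NC(=O)c3ccc(O)cc3)n2-c2c(C)cccc2C)cc1` gives 47900 nM in this assay, and this number sits beyond the scatter above compound 1. Going by the values given here, no two of the measured compounds differ in a single place, so no step between them can be read, and compound 3 differs from compound 1 in more than one place, so its higher number cannot be tied to any one change.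

Compound 4 `COc1ccc(-n2c(-c3ccc(Cl)cc3)cs/c2=N\NC(=O)c2ccc(O)cc2)c(OC)c1` has not been measured. It differs from compound 1 by chloro in place of methoxy on an aromatic carbon, para to a large group. Nothing in the three measured compounds isolates this change. The expected step from compound 1 to compound 4 is therefore none beyond the scatter, in either direction. Compound 4 is expected to give 17000 nM in this assay, with a range from 7000 nM to 40000 nM. The estimated step is no change at the digits printed from compound 1 to compound 4 (within the scatter).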

Compound 4, concentration for total growth inhibition: 83200 nM
Compound 4: middle estimate off by 4.9-fold (0.69 log units), on the low side; measured number outside the range, above it.
By their numbers in this assay, from the lowest: compounds 1, 2, 3 and 4 (each within the scatter of the next, the first and the last beyond it).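

In this assay chloro in place of methoxy on an aromatic carbon, para to a large group, gives a 4.9-fold higher number from compound 1 to compound 4 (0.69 log units; beyond the scatter). For the compounds shown here, this is the first comparison that differs in one place, and it shows that this position is not silent: with the rest of the core of compound 1 unchanged, going from 4-methoxyphenyl to 4-chlorophenyl moves the number beyond the scatter, towards weaker growth inhibition. Nothing on hand bears on what lies behind this step.

Still open is whether the step follows from the loss of methoxy or the arrival of chloro, since the compounds shown include no plain phenyl at this place. Also open, on these data alone, is how an amine, a carboxylic acid or a longer alkoxy chain would read at this position.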